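Piperazine for difluoropiperidine on the shared core

The source may hold more compounds than are shown below. What is called first, only, known or untested is meant among the compounds shown, and "the series" means these compounds.

Within the data shown here, compound 2 `Fc1ccccc1Cn1nc(-c2ncc(F)c(N3CCC(F)(F)CC3)n2)cc1-c1ccon1` gives 340 uL/min in an ADME assay on microsomes from liver (Rattus norvegicus) for pharmacokinetics (a higher number here means faster removal of the compound, a lower number slower removal), the higher of the two numbers measured so far; compound 1 `CNc1nc(-c2cc(-c3ccon3)n(Cc3ccccc3F)n2)ncc1F` gives 160 uL/min. Among the measured compounds shown here, the one measured step, a 2.1-fold higher number from compound 1 to compound 2 (0.33 log units; beyond the scatter), concerns the same aromatic carbon. Compound 3 `Fc1ccccc1Cn1nc(-c2ncc(F)c(N3CCNCC3)n2)cc1-c1ccon1` differs from compound 2 by piperazin-1-yl in place of 4,4-difluoropiperidin-1-yl on an aromatic carbon. For the measured compounds named here, no measured step covers this exchange directly, and the only step at that aromatic carbon was modest, so a change of similar or smaller size is expected, leaning toward a lower number. Compound 3 is therefore estimated at 230 uL/min, between 100 uL/min and 500 uL/min, an expected step of a 1.5-fold lower number from compound 2 to compound 3 (0.17 log units; within the scatter).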

Compound 3, intrinsic clearance in a liver preparation (reported as CLH), per the amount of preparation that the assay uses: 72 uL/min
Beside the measured number, compound 3's estimate is 3.2-fold (0.50 log units) above it, outside the stated range (below it).
By their numbers in this assay, from the lowest: compound 3; then compound 1; then compound 2.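

Read in this assay this aromatic carbon now moves the number both ways, since piperazin-1-yl gives a 4.7-fold lower number from compound 2 to compound 3 (0.67 log units; beyond the scatter) and also a 2.2-fold lower number from compound 1 to compound 3 (0.35 log units; beyond the scatter) and leaves compound 3 the lowest of the three. The earlier pair showed only a rise, with 4,4-difluoropiperidin-1-yl over methylamino. Nothing shown here accounts for the fall. The compounds shown leave open whether the lower number follows the hydrogen on the second ring nitrogen or the ring nitrogen itself. A morpholin-4-yl or 4-methylpiperazin-1-yl group on this carbon would separate the two.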